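Compound 4: fluorine in place of the six-heavy-atom group

The source may report more compounds than this note shows. Statements on the series, on what has been measured and on what is new or still open speak of the compounds shown alone.

Compound 3 `CC/C(=N/OC)c1ccc2oc(CSc3nnc(CNc4ccccc4)n3CC)nc2c1` stands at the top of what is shown: in an assay on isolated protein for inhibition of long-chain fatty acid transport protein 1 (Homo sapiens) (on this read-out higher numbers stand for weaker inhibition and lower numbers for stronger inhibition), compound 3 gives > 1000 nM, which is a limit of the assay and not a number. Compound 1 `CCn1c(CNc2ccccc2)nnc1SCc1nc2cc(Cl)ccc2o1` in this assay gives > 1000 nM, likewise a limit. Compound 2 `CCn1c(CNc2ccccc2)nnc1SCc1nc2cc(OC(F)(F)F)ccc2o1` in this assay gives 100 nM. The step of an at least 10-fold lower number from compound 1 to compound 2 (1.00 log units; beyond the scatter) accompanies trifluoromethoxy in place of chloro, and the step of an at least 10-fold higher number from compound 2 to compound 3 (1.00 log units; beyond the scatter) accompanies the larger group in place of trifluoromethoxy. The step that the two limits leave unreadable from compound 1 to compound 3 cannot be read because the limit of > 1000 nM in this assay, at which 2 of the 3 values shown sit, holds both of its ends.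

Compound 4 `CCn1c(CNc2ccccc2)nnc1SCc1nc2cc(F)ccc2o1` differs from compound 3 by one fluorine atom in place of a group of 6 heavy atoms (4 carbon, 1 nitrogen, 1 oxygen; no ring), on an aromatic carbon. The closest measured comparison is the chloro analogue, compound 1, which in this assay gives > 1000 nM, a limit. With fluoro the number of compound 4 is therefore expected to stay near that limit, and the step that the limit leaves unreadable from compound 3 to compound 4 is expected to be unreadable rather than a gain. Compound 4 is estimated at 1500 nM, within a range of 400 nM to 6000 nM.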

Compound 4, half-maximal inhibitory concentration: > 1000 nM
Compound 4 gave a limit, no number; the forecaster's own chance of this, stated with the estimate: 70%; the middle value lies beyond the limit too.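

Fluoro in place of trifluoromethoxy gives an at least 10-fold higher number from compound 2 to compound 4 (1.00 log units; beyond the scatter), so fluoro, like chloro, does not keep the value of compound 2. Of the four groups shown on this aromatic carbon, only trifluoromethoxy gives a readable value in this assay, while fluoro, chloro and the six-heavy-atom group cannot be ranked against one another. The steps to compound 4 from compound 1 and from compound 3 cannot be read, because their ends sit at one limit: the limit of > 1000 nM in this assay, at which 3 of the 4 values shown sit.

On these data alone, whether the value of compound 2 is tied to trifluoromethoxy alone stays open, and a methoxy or trifluoromethyl group on this aromatic carbon would bear on that. As far as these compounds go, all four compounds share the rest of the core, so the response to a change elsewhere, such as a longer chain in place of the ethyl group, also stays open.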